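Nitro on the far phenyl of a chalcone core

The source may hold more compounds than are shown below. What is called first, only, known or untested is meant among the compounds shown, and "the series" means these compounds.

Compound 1 `CC1(C)Cc2c(ccc(C(=O)/C=C/c3cn(-c4ccccc4)nc3-c3ccccc3)c2OCc2ccccc2)O1` sits at a limit of a functional assay on B16 cells (Mus musculus) for antiproliferative activity, read by MTT assay, with a stated time of 48 h; a higher number here means a weaker inhibitor, a lower number a stronger inhibitor: in this assay compound 1 gives > 100000 nM, a limit and not a number. Compound 2 `CC1(C)Cc2c(ccc(C(=O)/C=C/c3ccccc3)c2OCc2ccccc2)O1` likewise gives only a limit in this assay, > 100000 nM. Both shown values therefore rest on (the limit of > 100000 nM in this assay, at which 2 of the 2 values shown sit). Compound 3 `CC1(C)Cc2c(ccc(C(=O)/C=C/c3cn(-c4ccccc4)nc3-c3cccc([N+](=O)[O-])c3)c2OCc2ccccc2)O1` differs from compound 1 by nitro in place of hydrogen on an aromatic carbon. Within the data shown here, no measured step between two compounds is available to gauge such a change, so he expects no step beyond the scatter, a number no higher from compound 1 to compound 3 (the limit leaves the size open). For compound 3 he estimates 100000 nM, within 30000 nM to 300000 nM, most likely again reported only as a limit.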

Compound 3, half-maximal inhibitory concentration: > 50000 nM
Compound 3: only a limit was reported; the forecaster's own chance of this, stated with the estimate: 75%; the middle value does not contradict the limit.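

Among these compounds, compound 1 and compound 3 both give only limits in this assay, so no step between them can be read. The compounds shown leave open whether nitro in place of hydrogen changes the inhibitory concentration at all.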